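The source may hold more compounds than are shown below. What is called first, only, known or untested is meant among the compounds shown, and "the series" means these compounds.

Measured compounds:
- compound 1, `Cc1nc(NCc2ccccc2)nc(N[C@@H]2C[C@H](CO)[C@@H](O)[C@H]2O)c1-c1nc2cnccc2s1`: 25000 nM
- compound 2, `Cc1nc(N[C@@H](C)c2ccccc2)nc(N[C@@H]2C[C@H](CO)[C@@H](O)[C@H]2O)c1-c1nc2cnccc2s1`: 25000 nM
- compound 3, `CCc1nc(C)cc2sc(-c3c(C)nc(N[C@H](C)c4ccc(OC(F)(F)F)cc4)nc3N[C@@H]3C[C@H](CO)[C@@H](O)[C@H]3O)nc12`: 23000 nM

All three numbers come from an ADME assay on cells (Homo sapiens) for cytotoxicity, read by polymerase chain reaction, with a stated time of 3 days; a higher number here means that more compound is tolerated, a lower number that less compound is tolerated. In this assay compound 1 gives 25000 nM and compound 2 gives 25000 nM; the step between them, no change at the digits printed from compound 1 to compound 2 (within the scatter), is the change (methyl in place of hydrogen on a saturated chain carbon bound to an aromatic carbon and a nitrogen on an aromatic ring). Compound 3 gives 23000 nM in this assay, and its relation to compound 1 and compound 2 is shown by the values alone, since the difference between the core of compound 3 and the core of compound 1 is not broken down here.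

Compound 4, `CCc1cc2sc(-c3c(C)nc(N[C@H](C)c4ccc(OC(F)(F)F)cc4)nc3N[C@@H]3C[C@H](CO)[C@@H](O)[C@H]3O)nc2c(CC)n1`, has not yet been measured in this assay. It differs from compound 3 by methyl in place of hydrogen on a saturated chain carbon bound to an aromatic carbon. Among the compounds with values here, this is the same kind of change as the one from compound 1 to compound 2, but not the same: there the place is a saturated chain carbon bound to an aromatic carbon and a nitrogen on an aromatic ring, whereas in compound 4 the place is a saturated chain carbon bound to an aromatic carbon, with no nitrogen on an aromatic ring named at that place.

Within the data shown here, the one measured example of this kind of change, no change at the digits printed from compound 1 to compound 2 (within the scatter), left the number where it was. On that basis the expected step for compound 4 is no change at the digits printed from compound 3 to compound 4 (within the scatter), resting on the value of compound 3, 23000 nM, and on the flat step seen from compound 1 to compound 2. Compound 4 is therefore estimated at 23000 nM in this assay, with a range from 11000 nM to 45000 nM.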

Compound 4, half-maximal cytotoxic concentration: 12000 nM
Compound 4: middle estimate off by 1.9-fold (0.28 log units), on the high side; measured number inside the range.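

In this assay, methyl in place of hydrogen on a saturated chain carbon bound to an aromatic carbon gives a 1.9-fold lower number from compound 3 to compound 4 (0.28 log units; within the scatter). Set beside the earlier step on the other core, the two steps do not separate: the same change on two cores in this assay, no change at the digits printed (within the scatter) from compound 1 to compound 2 and a 1.9-fold lower number (0.28 log units; within the scatter) from compound 3 to compound 4, 1.9-fold (0.28 log units) apart, within the scatter of two such steps

Within the data shown here, on these two cores, then, the change leaves the number inside the usual scatter, and nothing here argues against carrying it from one core to the other; it does not show that the change would stay flat on a further core, as only two pairs stand behind the reading and the place is not identical, with a nitrogen on an aromatic ring named at the place in the earlier step and none named in the new one.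

The compounds shown leave open whether a longer chain such as propyl, or an amine or a carboxylic acid, at that saturated chain carbon would stay as flat in this assay as the methyl to ethyl difference does here. As far as these compounds go, how these same pairs read in any assay other than this assay also stays open.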